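This account rests on a few compounds, and the source may have more. Where it says the series, first, only, none or still open, it means among the compounds named here.

In a functional assay on HCT-116 cells (Homo sapiens) for inhibition, read by CCK-8 assay, with a stated time of 48 h (on this read-out higher numbers stand for weaker inhibition and lower numbers for stronger inhibition), compound 3 `COc1ccc(CN(C(=O)CSC(=S)N2CCN(C(=O)OC(C)(C)C)CC2)c2cc(OC)c(OC)c(OC)c2)cc1OC` gives > 20000 nM, which is a limit and not a number. Compound 2 `COc1cc(N(Cc2ccc(C)cc2)C(=O)CSC(=S)N2CCN(C(=O)OC(C)(C)C)CC2)cc(OC)c1OC` gives > 20000 nM, also a limit. Compound 1 `CCN1CCN(CC(=O)N(Cc2ccc(OC)cc2)c2cc(OC)c(OC)c(OC)c2)CC1` gives > 20000 nM, again a limit. Compound 4 `COc1ccc(CN(C(=O)CSC(=S)N2CCN(C(=O)OC(C)(C)C)CC2)c2cc(OC)c(OC)c(OC)c2)cc1N` differs from compound 3 at one place, with amino in place of methoxy on an aromatic carbon, ortho to a methoxy group: amino in place of methoxy on an aromatic carbon. Among the measured compounds shown here, the only measured step, a step that the two limits leave unreadable from compound 2 to compound 3, has no readable size and offers no guide to the size of this change. The expectation therefore stays close to the limit of > 20000 nM in this assay, at which 3 of the 3 values shown sit, with only a slight lean towards stronger inhibition. The estimated step is an at least 1.3-fold lower number from compound 3 to compound 4 (0.12 log units; that floor lies within the scatter), and it carries wide uncertainty. In this assay, compound 4 is expected at about 15000 nM, within an estimated range of 1000 nM to 40000 nM.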

Compound 4, half-maximal inhibitory concentration: 352 nM
Estimate against measurement, compound 4: 43-fold (1.63 log units) above; measured number outside the range, below it.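

In this assay, replacing one methoxy of the 3,4-dimethoxybenzyl group with amino gives an at least 56-fold lower number from compound 3 to compound 4 (1.75 log units; beyond the scatter), so this single place on the ring strongly affects the read-out. The wider swap of 4-methylphenyl for 3-amino-4-methoxyphenyl gives an at least 56-fold lower number from compound 2 to compound 4 (1.75 log units; beyond the scatter). Compound 4 is the only compound here whose value is not a limit: the limit of > 20000 nM in this assay, at which 3 of the 4 values shown sit.

Going by these compounds, only one replacement at this place appears, so it remains open whether gaining the amino group or losing the methoxy matters more. A hydroxyl or dimethylamino group there could help separate the two.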